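The compounds below may be only part of what the source reports. "The series", "measured", "known", "first", "only" and "open" are said of these compounds alone.

Measured so far in an ADME assay on MT4 cells (Homo sapiens) for cytotoxicity, read by MTT assay; on this read-out lower numbers stand for higher toxicity in this test and higher numbers for lower toxicity in this test:
- compound 1 `Cc1cc(C)cc(S(=O)(=O)c2c(C(=O)NCC(=O)NCc3ccncc3)[nH]c3ccc(Cl)cc23)c1` gives > 48900 nM as a limit
- compound 2 `Cc1cc(C)cc(S(=O)(=O)c2c(C(=O)NCc3cccc(N)c3)[nH]c3ccc(Cl)cc23)c1` gives > 53400 nM as a limit
- compound 3 `Cc1cc(C)cc(S(=O)(=O)c2c(C(=O)NCc3n[nH]c4ccccc34)[nH]c3ccc(Cl)cc23)c1` gives > 50700 nM as a limit

Compound 1 has no exact number in this assay and stands only at a limit, as do the other two compounds. Compound 4 `Cc1cc(C)cc(S(=O)(=O)c2c(C(=O)NCC(=O)NCCn3c(C)cnc3[N+](=O)[O-])[nH]c3ccc(Cl)cc23)c1` keeps the shared core and differs from compound 1 by a group of 10 heavy atoms (5 carbon, 3 nitrogen, 2 oxygen; one five-membered aromatic ring with 2 hetero atoms) in place of a group of 6 heavy atoms (5 carbon, 1 nitrogen; one six-membered aromatic ring with 1 hetero atom), on a saturated chain carbon bound to an amide-type nitrogen and has not yet been measured.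

Going by the values given here, three measured steps concern the same place, on a saturated chain carbon bound to an amide-type nitrogen. They are a step that the two limits leave unreadable from compound 1 to compound 2 and a step that the two limits leave unreadable from compound 1 to compound 3 and a step that the two limits leave unreadable from compound 2 to compound 3 and none of them has a size that can be read. None of them brings in the group found in compound 4. No readable step is therefore expected in this assay and no direction can be given.

The expected change is an at least 1.2-fold lower number from compound 1 to compound 4 (0.08 log units; that floor lies within the scatter) and it is offered with low confidence. The estimate for compound 4 is 40000 nM as the expected value, within an expected range from 15000 nM to 60000 nM and quite possibly reported only as a limit.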

Compound 4, half-maximal cytotoxic concentration: 24500 nM
Estimate against measurement, compound 4: 1.6-fold (0.21 log units) above, within the range that was stated.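

In this assay, going by these compounds alone, a step on a saturated chain carbon bound to an amide-type nitrogen can be read for the first time, as an at least 1.9-fold lower number from compound 1 to compound 4 (0.30 log units; that floor lies within the scatter). Its size is only a floor, since compound 1 stands at a limit: the limit of > 48900 nM in this assay, at which 1 of the 4 values shown sits. Compound 1, compound 2 and compound 3 all stand at limits and the steps among them cannot be read, whereas compound 4 carries an exact number.

The compounds shown do not separate the parts of the entering group, so it remains open whether the nitro group, the methyl group or the five-membered aromatic ring goes with the lower number. As far as these compounds go, how a carboxylic acid or a simple dimethylamino group at this place would read in this assay also remains open.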